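This account rests on a few compounds, and the source may have more. Where it says the series, first, only, none or still open, it means among the compounds named here.

Compound 1, `COc1cc(COC(c2ccc(OC)c(OC)c2OC)c2cccc3ccccc23)cc(OC)c1`: > 20000 nM
Compound 2, `COc1ccc(/C(=C/c2ccc(C)cc2)c2cccc3ccccc23)c(OC)c1OC`: > 20000 nM

In a functional assay on THP-1 cells (Homo sapiens) for inhibition, read by sulforhodamine B assay, with a stated time of 48 h (on this read-out lower numbers stand for stronger inhibition and higher numbers for weaker inhibition), compound 1 gives only a limit of the assay, > 20000 nM, not a number. Compound 2 likewise reaches only a limit in this assay, > 20000 nM. For the measured compounds named here, the whole picture so far is the limit of > 20000 nM in this assay, at which 2 of the 2 values shown sit, so no measured step exists to set a scale. Compound 3, `COc1ccc(C(OCc2ccc(C)cc2)c2cccc3ccccc23)c(OC)c1OC`, differs from compound 1 by 4-methylphenyl in place of 3,5-dimethoxyphenyl on a saturated chain carbon bound to an oxygen on a saturated carbon. With both known values at the limit, the step is expected to stay within the scatter or run slightly weaker; the expected step is a step that the limit leaves unreadable from compound 1 to compound 3. Compound 3 is estimated at 30000 nM, between 10000 nM and 100000 nM, most likely again as a limit.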

Compound 3, half-maximal inhibitory concentration: > 20000 nM
Compound 3: a limit, no number (the forecaster's own chance of this, stated with the estimate: 80%); the middle value does not contradict the limit.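

For the compounds shown here, compound 3 gives only a limit of the assay (> 20000 nM), not a number, so no step from compound 1 to compound 3 can be read. The compounds shown leave open which change to the shared core, if any, would give a number in this assay instead of a limit: the limit of > 20000 nM in this assay, at which 3 of the 3 values shown sit.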